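Replacing a Hydroxyphenyl with a Pyridyl Ring on the Hydrazone Nitrogen

The compounds below may be only part of what the source reports. "The series", "measured", "known", "first", "only" and "open" are said of these compounds alone.

Of the compounds shown here, three sharing one core have been tested in a functional assay on the whole organism with Rattus norvegicus as the target; on this read-out lower numbers stand for an effect already at smaller amounts and higher numbers for an effect only at larger amounts of compound. Compound 1 `C[C@@H]1CC/C(=N\Nc2ccccc2)c2ncc(C(=O)O)c(=O)n21` gives 54.8 umol/kg. Compound 2 `CC1CCC(/C=N/c2ccccc2C(=O)O)=C2NC=C(C(=O)O)C(=O)N21` gives 1.11 umol/kg, the lowest number of the three. Compound 3 `CC1CCC(/C=N/c2ccccc2O)=C2NC=C(C(=O)O)C(=O)N21` gives 4.11 umol/kg, the second highest of the three numbers; it sits a 3.7-fold higher number from compound 2 to compound 3 (0.57 log units; beyond the scatter) and well below compound 1. Within the data shown here, the only single-point step measured so far is the one with a 3.7-fold higher number from compound 2 to compound 3 (0.57 log units; beyond the scatter), in which a hydroxy replaces a carboxy on an aromatic carbon.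

Compound 4 `CC1CCC(/C=N/c2cccnc2)=C2NC=C(C(=O)O)C(=O)N21` is the next step. It differs from compound 3 by pyridin-3-yl in place of 2-hydroxyphenyl on a double-bonded nitrogen. Among the measured compounds shown here, no measured pair shows exactly this exchange; the step from compound 2 to compound 3 bears on it only in showing that what sits on that aromatic ring shifts the number by a modest amount. In compound 4 the hydroxy is gone and a ring nitrogen enters instead, so a step of similar size, towards a higher number, is expected, though a flat result within the scatter is also possible. Compound 4 is therefore estimated at 8 umol/kg, with a range from 2.5 umol/kg to 25 umol/kg, meaning an expected step of a 1.9-fold higher number from compound 3 to compound 4 (0.29 log units; within the scatter).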

Compound 4, dose for 50% inhibition: 2.4 umol/kg
Compound 4: the middle estimate sits 3.3-fold (0.52 log units) above what was measured; measured number outside the range, below it.
By their numbers in this assay, from the lowest: compound 2; then compounds 4 and 3 (each within the scatter of the next); then compound 1.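

In this assay, exchanging 2-hydroxyphenyl for pyridin-3-yl on the double-bonded nitrogen gives a 1.7-fold lower number from compound 3 to compound 4 (0.23 log units; within the scatter), so compound 3 and compound 4 cannot be told apart on this read-out. The earlier step, a 3.7-fold higher number from compound 2 to compound 3 (0.57 log units; beyond the scatter), showed that swapping one group on the aromatic ring can move the number beyond the scatter, whereas this step shows that a larger change at the same place, replacing the whole ring and removing the hydroxy, need not do so. Nothing available explains why the number holds in this exchange.

This step makes two changes at once, removing the hydroxy and adding a ring nitrogen, so the compounds shown leave open what each change does alone, and whether the two offset each other or both have little effect; a plain phenyl on the same double-bonded nitrogen would separate them. Also open, as far as these compounds go, is whether the place of the ring nitrogen matters, as pyridin-2-yl or pyridin-4-yl would show, and whether an amine on the phenyl ring would behave like the hydroxy.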